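This account rests on a few compounds, and the source may have more. Where it says the series, first, only, none or still open, it means among the compounds named here.

Working notes on the series. In an ADME assay on cells (Hepatocyte, Mus musculus) for metabolic stability, read by LC-MS, with a stated time of 180 min, tested at 1 uM (a lower number here means slower removal, a higher number faster removal of the compound), compound 1 `CCC(C(=O)O)c1nn(Cc2cn3cc(OCC4CC4)c(Cl)cc3n2)c2ccccc2c1=O` gives 155 mL/min/kg, the highest of the two numbers in hand. Going by the values given here, compound 2 `C[C@H](C(=O)O)n1nc(Cn2cc3cc(OCC4CC4)c(Cl)cc3n2)c2ccccc2c1=O` gives 63.3 mL/min/kg in this assay; that number lies below the one for compound 1 by a gap beyond the usual scatter, but the two structures differ in more than one place, so no single step connects them and the pair shows only what its two values show.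

Compound 3 `C[C@H](C(=O)O)c1nn(Cc2cn3cc(OCC4CC4)c(Cl)cc3n2)c2ccccc2c1=O` has not yet been measured in this assay. It differs from compound 1 in one place: 1-carboxyethyl in place of 1-carboxypropyl on an aromatic carbon. Among the compounds with values here, no measured step of this kind exists in the set, so the expectation rests on compound 1 and on the change itself, with the lower reading of compound 2 noted only as the sole other number available. The step of a 1.4-fold lower number from compound 1 to compound 3 (0.15 log units; within the scatter) is expected to be modest, in the direction of slower removal, and could stay within the scatter. For compound 3 the estimate in this assay is 110 mL/min/kg, with a range from 60 mL/min/kg to 180 mL/min/kg.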

Compound 3, clearance in the Hepatocyte assay: 33.3 mL/min/kg
For compound 3 the middle estimate is 3.3-fold (0.52 log units) above the measured one; the whole stated range lies above it.
By their numbers in the Hepatocyte assay, from the lowest: compounds 3 and 2 (each within the scatter of the next); then compound 1.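

Going by these compounds alone, at this place, on an aromatic carbon next to the ring nitrogen, 1-carboxyethyl in place of 1-carboxypropyl is the only single change in hand, and in the Hepatocyte assay it gives a 4.7-fold lower number from compound 1 to compound 3 (0.67 log units; beyond the scatter). Compound 1 and compound 2 differ in more than one place and could show nothing of this kind, whereas this step shows that a change confined to this side chain is enough to move the clearance beyond the scatter. The same change also counts for solubility, where in a physicochemical assay for solubility, measured as thermodynamic solubility, at pH 7.4 (on this read-out higher numbers stand for higher solubility and lower numbers for lower solubility), compound 1 gives 359 ug/mL and compound 3 gives 892 ug/mL, so that here the lower clearance and the higher solubility come together in one step: the measured solubility of compound 1, 359 ug/mL, and of compound 3, 892 ug/mL, a 2.5-fold higher number (0.40 log units; beyond the scatter)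

The 1-carboxyethyl group also brings a defined stereocentre, so this single step cannot separate the effect of the shorter chain from that of the stereocentre. On these data alone, how a carboxymethyl group, a longer chain such as 1-carboxybutyl, or an amide in place of the carboxylic acid would read at this position stays open, as does whether the two read-outs would move together there.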